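Chain-lengthened homologues of an acyl-homoserine lactone series

A few compounds are considered here, and "the series" means these few. Any claim that something is new, unique, unknown or untested is made for them only; others in the source may bear on it.

Compound 1 `O=C(CCCCCCCCCCc1ccccc1)CC(=O)N[C@H]1CCOC1=O` gives 14000 nM in a functional assay on NCI-H630 cells (Homo sapiens) for cytotoxicity, read by sulforhodamine B assay, with a stated time of 5 days; on this read-out lower numbers stand for stronger inhibition and higher numbers for weaker inhibition.
Compound 2 `O=C(CCCCCCCCc1ccccc1)CC(=O)N[C@H]1CCOC1=O` gives 10000 nM in this assay.
Compound 3 `O=C(CCCCCCCCCc1ccccc1)CC(=O)N[C@H]1CCOC1=O` gives 13000 nM in this assay.

Compound 3 is second highest of the three numbers, nearest to compound 1 and furthest from compound 2, with both gaps within the scatter. Compound 4 `O=C(CCCCCCCCCCCc1ccccc1)CC(=O)N[C@H]1CCOC1=O` differs from compound 3 by phenethyl in place of phenyl on a saturated chain carbon, nine bonds along the chain from a carbonyl carbon. The relevant measured steps all lie within the scatter: a 1.1-fold lower number from compound 1 to compound 3 (0.03 log units; within the scatter), a 1.3-fold higher number from compound 2 to compound 3 (0.11 log units; within the scatter) and a 1.4-fold lower number from compound 1 to compound 2 (0.15 log units; within the scatter). Since none of these shifts the number beyond the scatter, compound 4 is expected to sit close to compound 3, with a 1.1-fold higher number from compound 3 to compound 4 (0.03 log units; within the scatter) as the expected step. Compound 4 is therefore estimated at 14000 nM in this assay, with a range from 7000 nM to 28000 nM.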

Compound 4, half-maximal inhibitory concentration: 27000 nM
For compound 4 the middle estimate is 1.9-fold (0.29 log units) below the measured one; low and high end bracket the measured number.
By their numbers in this assay, from the lowest: compounds 2, 3, 1 and 4 (each within the scatter of the next, the first and the last beyond it).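

Within the data shown here, compound 4 gives the first steps beyond the scatter in this assay: phenethyl in place of phenyl gives a 2.1-fold higher number from compound 3 to compound 4 (0.32 log units; beyond the scatter), and 3-phenylpropyl in place of phenyl gives a 2.7-fold higher number from compound 2 to compound 4 (0.43 log units; beyond the scatter). Compound 1 does not separate from it, as benzyl in place of phenyl gives a 1.9-fold higher number from compound 1 to compound 4 (0.29 log units; within the scatter). The same change read on two cores agrees, so the longer chain shows no clear dependence on the core: the same change on two cores in this assay, a 1.4-fold lower number (0.15 log units; within the scatter) from compound 1 to compound 2 and a 2.1-fold lower number (0.32 log units; beyond the scatter) from compound 4 to compound 3, 1.5-fold (0.17 log units) apart, within the scatter of two such steps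

Going by these compounds, whether a still longer chain raises the number further remains open. So does the effect of a carboxylic acid in place of the phenyl.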